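The compounds below may be only part of what the source reports. "The series", "measured", "known", "first", "only" and "open" are said of these compounds alone.

Working notes on the series. Going by the values given here, in a functional assay on Shh Light II cells (Mus musculus) for inhibition, read by a luciferase reporter (on this read-out lower numbers stand for stronger inhibition and higher numbers for weaker inhibition), compound 1 `N#Cc1ccccc1NC(=O)N1CCC(c2nc(-c3ccc4ccccc4n3)no2)CC1` gives 190 nM, the lowest of the three numbers so far. Compound 3 `Cn1c(-c2noc(C3CCN(C(=O)NC4CCS(=O)(=O)CC4)CC3)n2)nc2ccccc21` gives 350 nM in this assay, which lies within the scatter of compound 1, so no order between the two is claimed. Compound 2 `COc1ccccc1NC(=O)N1CCC(c2noc(-c3ccc4ccccc4n3)n2)CC1` gives 2400 nM in this assay, a gap to compound 1 that is beyond the scatter; compound 2 also carries a core that differs from that of compound 1, so its value is read on its own.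

Compound 4 `O=C(NC1CCS(=O)(=O)CC1)N1CCC(c2nc(-c3ccc4ccccc4n3)no2)CC1` has not yet been measured. It differs from compound 1 by 1,1-dioxothian-4-yl in place of 2-cyanophenyl on an amide-type nitrogen. Among the compounds with values here, compound 3 carries the same 1,1-dioxothian-4-yl amide on a different core and gives 350 nM, which is the only guide here. The step in this assay is expected to be small, towards a higher number, at about a 1.8-fold higher number from compound 1 to compound 4 (0.27 log units; within the scatter), likely within or close to the scatter. Compound 4 is therefore estimated at 350 nM, with a range of 120 nM to 1000 nM in this assay.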

Compound 4, half-maximal inhibitory concentration: 360 nM
For compound 4 the middle estimate is 1.0-fold (0.01 log units) below the measured one, and the stated range covers the measured number.
By their numbers in this assay, from the lowest: compounds 1, 3 and 4 (each within the scatter of the next); then compound 2.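

On the core of compound 1, 1,1-dioxothian-4-yl in place of 2-cyanophenyl on an amide-type nitrogen gives a 1.9-fold higher number from compound 1 to compound 4 (0.28 log units; within the scatter) in this assay, so this read-out does not separate an aromatic ring of carbon only from a non-aromatic ring with a hetero atom at this place. With 1,1-dioxothian-4-yl held constant, quinolin-2-yl in place of 1-methyl-1H-benzimidazol-2-yl on an aromatic carbon gives a 1.0-fold higher number from compound 3 to compound 4 (0.01 log units; within the scatter) and so does not separate these two groups either. No data at hand offer an explanation for these two steps.

Still open, going by these compounds, is whether an unsubstituted phenyl, a methyl or a piperidin-4-yl on the same nitrogen would stay within the scatter of these values. Compound 2 has a different core, so its gap cannot be assigned to any single change.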